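Demethylation step across two chalcone cores

This account rests on a few compounds, and the source may have more. Where it says the series, first, only, none or still open, it means among the compounds named here.

Compound 1 `COc1ccc(/C=C/C(=O)c2ccccc2-c2cccc(F)c2)cc1OC` and compound 2 `COc1ccc(/C=C/C(=O)c2ccccc2-c2cccc(F)c2)cc1O` share a core; compound 3 `COc1ccc(C(=O)/C=C/c2ccccc2-c2ccc(F)cc2)cc1OC` and compound 4 `COc1cc(C(=O)/C=C/c2ccccc2-c2ccc(F)cc2)ccc1O` share another. In a functional assay on A549 cells (Homo sapiens) for antiproliferative activity, read by sulforhodamine B assay, with a stated time of 48 h (on this read-out higher numbers stand for weaker inhibition and lower numbers for stronger inhibition), compound 1 gives 330 nM and compound 2 gives 11 nM, a step of a 30-fold lower number from compound 1 to compound 2 (1.48 log units; beyond the scatter) made by hydrogen in place of methyl on an oxygen on an aromatic ring. Compound 3 gives 7500 nM in this assay, the highest number of the three measured. How the core of compound 3 differs from that of compound 1 is not broken down here. The same change, (hydrogen in place of methyl on an oxygen on an aromatic ring), leads from compound 3 to compound 4. Going by the values given here, a step smaller than the measured one is expected, since the cores differ and only one instance of the change has been measured; compound 4 is estimated at a 5.0-fold lower number from compound 3 to compound 4 (0.70 log units; beyond the scatter) in this assay. Compound 4 is accordingly expected near 1500 nM, between 300 nM and 6000 nM.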

Compound 4, half-maximal inhibitory concentration: 4600 nM
Compound 4: middle estimate off by 3.1-fold (0.49 log units), on the low side; low and high end bracket the measured number.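

In this assay the change from methoxy to hydroxy gives a 1.6-fold lower number from compound 3 to compound 4 (0.21 log units; within the scatter) and so does not carry its size from one core to the other: the same change on two cores in this assay, a 30-fold lower number (1.48 log units; beyond the scatter) from compound 1 to compound 2 and a 1.6-fold lower number (0.21 log units; within the scatter) from compound 3 to compound 4, 18-fold (1.26 log units) apart, beyond the scatter of two such steps

The large gain seen at compound 2 therefore holds for the core of compound 1 and cannot be assumed on another core. With a single pair on each core, the data do not show which difference between the cores goes with the gap, or how the change would behave on a third core.

Still open, from the compounds shown here alone, is whether an amine or a carboxylic acid in place of the hydroxy would keep the low number of compound 2. Going by these compounds, it is also open whether an ethoxy group would behave like methoxy on either core.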